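From Acetoxymethyl to 1-Hydroxyethyl on a Shared Core

The source may hold more compounds than are shown below. What is called first, only, known or untested is meant among the compounds shown, and "the series" means these compounds.

In a functional assay on HeLa cells (Homo sapiens) for cytotoxicity, read by MTT assay (a lower number here means a stronger inhibitor, a higher number a weaker inhibitor), compound 3 (`CC(=O)OCCO[C@H](CC=C(C)C)C1=CC(=O)c2c(O)ccc(O)c2C1=O`) gives 41500 nM and sits within the scatter of both measured relatives. Compound 1 (`CC(C)=CC[C@@H](OC(=O)CCO)C1=CC(=O)c2c(O)ccc(O)c2C1=O`) gives 67600 nM there, and compound 2 (`CCCC(O)CC(=O)O[C@H](CC=C(C)C)C1=CC(=O)c2c(O)ccc(O)c2C1=O`) gives 59300 nM there. Compound 4 (`CC(C)=CC[C@@H](OCC(C)O)C1=CC(=O)c2c(O)ccc(O)c2C1=O`) differs from compound 3 on a saturated chain carbon bound to an oxygen on a saturated carbon, with 1-hydroxyethyl in place of acetoxymethyl (1-hydroxyethyl in place of acetoxymethyl on a saturated chain carbon bound to an oxygen on a saturated carbon). Among the compounds with values here, no measured step makes this exact change. Two steps that exchange the whole group on that oxygen bear on it: a 1.6-fold lower number from compound 1 to compound 3 (0.21 log units; within the scatter) and a 1.4-fold lower number from compound 2 to compound 3 (0.16 log units; within the scatter) (both small). Adding propyl gives a 1.1-fold lower number from compound 1 to compound 2 (0.06 log units; within the scatter) and that step is small as well. In this assay no step beyond the scatter is therefore expected, and no direction can be claimed with confidence. The estimated step is a 1.3-fold higher number from compound 3 to compound 4 (0.12 log units; within the scatter) in size. For compound 4 the estimate is 55000 nM with an expected range of 28000 nM to 105000 nM around it.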

Compound 4, half-maximal inhibitory concentration: 24700 nM
The estimate for compound 4 lay 2.2-fold (0.35 log units) above the measured number, and the stated range ends above it.
By their numbers in this assay, from the lowest: compounds 4, 3, 2 and 1 (each within the scatter of the next, the first and the last beyond it).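

In this assay the exchange of acetoxymethyl for 1-hydroxyethyl on a saturated chain carbon bound to an oxygen on a saturated carbon gives a 1.7-fold lower number from compound 3 to compound 4 (0.23 log units; within the scatter) and so stays within the scatter on its own. Set against the two groups that place a carbonyl on that oxygen, however, 2-hydroxypropyl gives the first steps beyond the scatter at this position, with a 2.4-fold lower number from compound 2 to compound 4 (0.38 log units; beyond the scatter) and a 2.7-fold lower number from compound 1 to compound 4 (0.44 log units; beyond the scatter) as modest changes. Compound 3 also has no carbonyl directly on that oxygen yet stays within the scatter of compound 1 and compound 2, so losing that carbonyl does not by itself go with a step beyond the scatter. Nothing available gives a reason for these steps. Going by these compounds, whether an amine in place of the hydroxyl of 2-hydroxypropyl, or a longer chain such as 2-hydroxypentyl on that same oxygen, would hold this level stays open.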